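This account rests on a few compounds, and the source may have more. Where it says the series, first, only, none or still open, it means among the compounds named here.

Of the compounds shown here, three built on a shared core have so far been measured in a functional assay on MCF7 cells (Homo sapiens) for cytotoxicity, read by sulforhodamine B assay; a lower number here means a stronger inhibitor, a higher number a weaker inhibitor. Compound 1 `C=C1CC[C@@H]2[C@](C)(CO[Si](C)(C)C(C)(C)C)[C@H](OC(C)=O)CC[C@@]2(C)[C@@H]1C/C=C1/C(=O)OC[C@H]1OC(C)=O` gives 4840 nM. Compound 2 `C=C1[C@@H](OC(C)=O)C[C@@H]2[C@](C)(COC=O)[C@H](OC(C)=O)CC[C@@]2(C)[C@@H]1C[C@@H](Nc1cccc2ccccc12)C1=CCOC1=O` gives 9750 nM, and compound 3 `C=C1[C@@H](OC(C)=O)C[C@@H]2[C@](C)(CO[Si](C)(C)C(C)(C)C)[C@H](OC(C)=O)CC[C@@]2(C)[C@@H]1C[C@@H](Nc1cccc2ccccc12)C1=CCOC1=O` gives 5770 nM. Compound 2 holds the highest of the three numbers, but its neighbours sit close: the step of a 1.7-fold lower number from compound 2 to compound 3 (0.23 log units; within the scatter) lies within the scatter, and the number of compound 1 lies within the scatter of compound 2 as well, so none of the three can be set apart from the others.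

Compound 4 `C=C1[C@@H](OC(C)=O)C[C@@H]2[C@](C)(COC=O)[C@H](OC(C)=O)CC[C@@]2(C)[C@@H]1C[C@@H](Nc1ccc(F)cc1)C1=CCOC1=O` has not yet been measured. It differs from compound 2 in one place: 4-fluorophenyl in place of naphthalen-1-yl on an amine nitrogen. Among the compounds with values here, the only step measured so far, a 1.7-fold lower number from compound 2 to compound 3 (0.23 log units; within the scatter), concerns a group on an oxygen on a saturated carbon and not the amine nitrogen, so no measured pair bears directly on this change. Within the data shown here, with the three known numbers lying close together and no step touching this position, there is no basis for expecting a shift in either direction.

The step from compound 2 to compound 4 is therefore expected to stay within the scatter, as a 1.1-fold lower number from compound 2 to compound 4 (0.03 log units; within the scatter). In this assay compound 4 is estimated at 9000 nM, with a range from 3500 nM to 25000 nM.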

Compound 4, half-maximal inhibitory concentration: 12400 nM
Compound 4: the middle estimate sits 1.4-fold (0.14 log units) below what was measured; measured number inside the range.
By their numbers in this assay, from the lowest: compounds 1, 3, 2 and 4 (each within the scatter of the next, the first and the last beyond it).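

In this assay, within the data shown here, the exchange of naphthalen-1-yl for 4-fluorophenyl on the amine nitrogen gives a 1.3-fold higher number from compound 2 to compound 4 (0.10 log units; within the scatter), and this is the first reading at a position that no earlier step touched. Going from a group of 10 heavy atoms with two six-membered aromatic rings to one of 7 heavy atoms with a single such ring and a fluorine leaves compound 2 and compound 4 indistinguishable in this assay, so this one change at this position leaves no effect that can be read. No measurement at hand bears on why the two compounds cannot be told apart.

This single pair leaves open whether other groups on the same amine nitrogen, such as a plain phenyl, a cyclohexyl, or a phenyl carrying a carboxylic acid, would stay within the scatter of compound 2 or move clearly away from it. It also leaves open whether the same exchange would read the same way with the silicon-bearing group of compound 3 on the oxygen in place of the group that compound 2 and compound 4 carry there.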